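Chloro to hydrogen: from compound 2 to compound 4

The compounds below may be only part of what the source reports. "The series", "measured", "known", "first", "only" and "open" are said of these compounds alone.

All four compounds share one core. In a functional assay on A498 cells (Homo sapiens) for inhibition, read by sulforhodamine B assay, with a stated time of 48 h (on this read-out lower numbers stand for stronger inhibition of growth and higher numbers for weaker inhibition of growth), compound 1 `N=C(N)c1ccc(-c2ccc(-c3cc(Cl)cc(Cl)c3)s2)cc1` is recorded as "not determined" (no result reported). In this assay compound 2 `N=C(N)c1ccc(-c2ccc(-c3ccc(Cl)cc3)s2)cc1F` gives 1380 nM, and compound 3 `COc1cc(OC)cc(-c2ccc(-c3ccc(C(=N)N)c(F)c3)s2)c1` gives 1330 nM. Of the two numbers, that of compound 2 is the higher, yet its gap to compound 3 lies within the scatter, so the two cannot be told apart. Compound 4 `N=C(N)c1ccc(-c2ccc(-c3ccccc3)s2)cc1F` differs from compound 2 by hydrogen in place of chloro on an aromatic carbon. Among the measured compounds shown here, no measured pair shows this change, so its size is open; a modest shift toward weaker inhibition of growth, near the edge of the scatter, is expected, a 1.6-fold higher number from compound 2 to compound 4 (0.20 log units; within the scatter). Compound 4 is estimated to give 2200 nM in this assay, with a range from 900 nM to 5500 nM.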

Compound 4, concentration for 50% growth inhibition: 12800 nM
Estimate against measurement, compound 4: 5.8-fold (0.76 log units) below; measured number above the stated range.
By their numbers in this assay, from the lowest: compounds 3 and 2 (each within the scatter of the next); then compound 4.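

Across the shared core, the change from 4-chlorophenyl to phenyl gives the first readable step at this position: in this assay the step is a 9.3-fold higher number from compound 2 to compound 4 (0.97 log units; beyond the scatter) and lies beyond the scatter. The chloro on this aromatic carbon therefore matters to the read-out, which compounds 2 and 3 alone could not show. No measurement on hand accounts for the size of this step.

Still open, going by these compounds, is whether an amine or a carboxylic acid at this position would stay near compound 2 or near compound 4. Also open, on these data alone, is whether bromo would match chloro here.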